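The source may report more compounds than this note shows. Statements on the series, on what has been measured and on what is new or still open speak of the compounds shown alone.

Working notes on the series. Going by the values given here, in a physicochemical assay for pharmacokinetics (a higher number here means that the compound lasts longer, a lower number that the compound disappears faster), compound 1 (`O=C(NCc1ccccc1Cl)N1C(=O)c2ccccc2S1(=O)=O`) gives 0.42 h and holds the only numeric reading so far. Compound 2 (`O=C(c1ccccc1)N1Cc2ccccc2S1(=O)=O`) reads > 166 h as a limit of this assay and not a number. Among the compounds with values here, no step between measured compounds that differ in one place is available, so compound 1 at 0.42 h is the sole anchor for what follows.

The next compound is compound 3 (`COc1ccccc1CNC(=O)N1C(=O)c2ccccc2S1(=O)=O`). Its difference from compound 1 is methoxy in place of chloro on an aromatic carbon and amounts to methoxy in place of chloro on an aromatic carbon, ortho to a large group. In this assay no shift beyond the usual scatter is expected, and no direction is favoured. The estimated 1.1-fold higher number from compound 1 to compound 3 (0.03 log units; within the scatter) is therefore expected to stay small. For compound 3 the expected half-life is 0.45 h with an estimated range of 0.2 h to 1 h for this reading.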

Compound 3, half-life: 1.12 h
Beside the measured number, compound 3's estimate is 2.5-fold (0.40 log units) below it, outside the stated range (above it).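

In this assay the aromatic carbon ortho to a large group proves responsive to substitution: methoxy in place of chloro gives a 2.7-fold higher number from compound 1 to compound 3 (0.43 log units; beyond the scatter) and so moves the half-life beyond the usual scatter, though only modestly. Going by these compounds alone, this is the only change in one place that the series can be read from so far, and a single pair gives a size for this exchange, not a trend. No measured property among the data shown accounts for the step.

Going by these compounds, whether other groups on the same aromatic carbon, such as an amine or a carboxylic acid, would also move the half-life remains open. On these data alone, compound 2 differs in more than one place and its reading in this assay is a limit and not a number, so the link between its core and the half-life also remains open.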